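This account rests on a few compounds, and the source may have more. Where it says the series, first, only, none or still open, it means among the compounds named here.

Compound 1, `CCc1cc2ccccc2nc1-c1cc(-c2ccccc2)no1`, in a functional assay on A549 cells (Homo sapiens) for inhibition, read by MTT assay, with a stated time of 24 h (a higher number here means a weaker inhibitor, a lower number a stronger inhibitor), gives > 100000 nM, which is a limit of the assay and not a number. Compound 2, `CCCc1cc2ccccc2nc1-c1cc(-c2ccccc2)no1`, in this assay gives 52500 nM. Compound 3, `CCCc1cc2ccccc2nc1-c1cc(-c2ccc(F)cc2)no1`, in this assay gives 51300 nM.

The change from compound 1 to compound 2 is methyl in place of hydrogen on a saturated chain carbon, two bonds along the chain from an aromatic carbon and yields an at least 1.9-fold lower number from compound 1 to compound 2 (0.27 log units; that floor lies within the scatter), a floor set by the limit of > 100000 nM in this assay, at which 1 of the 3 values shown sits. Between compound 2 and compound 3 the fluoro for hydrogen gives a 1.0-fold lower number from compound 2 to compound 3 (0.01 log units; within the scatter). Compound 4, `CCCCc1cc2ccccc2nc1-c1cc(-c2ccc(F)cc2)no1`, is not yet measured; it differs from compound 3 by methyl in place of hydrogen on a saturated chain carbon, three bonds along the chain from an aromatic carbon, the same kind of change as the earlier one, though placed three bonds rather than two bonds along the chain from an aromatic carbon. How the cores of compound 1 and compound 3 differ is not broken down here. Because the earlier step reads only an at least 1.9-fold lower number from compound 1 to compound 2 (0.27 log units; that floor lies within the scatter), the expected step for compound 4 in this assay is a 1.5-fold lower number from compound 3 to compound 4 (0.17 log units; within the scatter), within the scatter. Compound 4 is estimated at 35000 nM, with a range from 12000 nM to 100000 nM.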

Compound 4, half-maximal inhibitory concentration: 27500 nM
Compound 4: middle estimate off by 1.3-fold (0.10 log units), on the high side; measured number inside the range.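

In this assay, methyl in place of hydrogen on a saturated chain carbon, three bonds along the chain from an aromatic carbon, gives a 1.9-fold lower number from compound 3 to compound 4 (0.27 log units; within the scatter). Neither this step nor the earlier one lies beyond the scatter, so the series shows no firm gain carried from one core to the other, and no failure to carry either: the same change on two cores in this assay, an at least 1.9-fold lower number (0.27 log units; that floor lies within the scatter) from compound 1 to compound 2 and a 1.9-fold lower number (0.27 log units; within the scatter) from compound 3 to compound 4; the limit leaves it open whether they differ. The earlier step starts from compound 1, whose value is a limit of the assay and not a number: the limit of > 100000 nM in this assay, at which 1 of the 4 values shown sits.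

The compounds shown leave open whether a longer chain, an amine or a carboxylic acid in place of the butyl group would give a step beyond the scatter in this assay.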